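This account rests on a few compounds, and the source may have more. Where it says the series, first, only, none or still open, it means among the compounds named here.

Compound 3 `CCCCCCCCCCc1ccc(-c2noc(CC3CNC3)n2)cc1` gives 63% in an assay on HeLa cells for inhibition of sphingosine-1-phosphate transporter SPNS2 (Mus musculus), read by LC-MS, tested at 2 uM (on this read-out lower numbers stand for less inhibition and higher numbers for more inhibition at the one concentration tested (going by the name of the read-out)), and stands highest of the three numbers measured; compound 1 `CCCCCCCCCCc1ccc(-c2noc(CCCNC)n2)cc1` gives 45% and compound 2 `CCCCCCCCCCc1ccc(-c2noc(CCCN(C)C)n2)cc1` gives 8%. The measured steps are a number 37 percentage points lower from compound 1 to compound 2 (beyond the scatter), a number 18 percentage points higher from compound 1 to compound 3 (beyond the scatter) and a number 55 percentage points higher from compound 2 to compound 3 (beyond the scatter). Compound 4 `CCCCCCCCCCc1ccc(-c2noc(C3CCNCC3)n2)cc1` differs from compound 3 by piperidin-4-yl in place of (azetidin-3-yl)methyl on an aromatic carbon. For the measured compounds named here, no measured step changes a ring size; the two steps into compound 3, a number 18 percentage points higher from compound 1 to compound 3 (beyond the scatter) and a number 55 percentage points higher from compound 2 to compound 3 (beyond the scatter), show that the ring amine beat both open chains, and compound 4 keeps a ring amine with one hydrogen-bond donor. A step of a number 8 percentage points lower from compound 3 to compound 4 (within the scatter) is therefore expected, within the scatter. Compound 4 is estimated at 55%, in the range 35% to 75%.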

Compound 4, a percentage reported as inhibition, at one concentration (the size of the read-out at that concentration, not a potency): 66%
For compound 4 the middle estimate is 11 percentage points below the measured one; measured number inside the range.
By their numbers in this assay, from the lowest: compound 2; then compound 1; then compounds 3 and 4 (each within the scatter of the next).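

In this assay, piperidin-4-yl in place of (azetidin-3-yl)methyl gives a number 3 percentage points higher from compound 3 to compound 4 (within the scatter), so these two ring amines cannot be told apart at this position. The gain over the open chains is therefore not limited to the four-membered ring, as the six-membered ring also shows a number 21 percentage points higher from compound 1 to compound 4 (beyond the scatter) and a number 58 percentage points higher from compound 2 to compound 4 (beyond the scatter). Nothing available explains why these ring amines match each other or exceed the open chains. The compounds shown leave open how a pyrrolidin-3-yl group would compare, and whether a methyl on the piperidine nitrogen would bring a drop like that seen between the open chains.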